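A Methylene Link Tested on a Shared Core

The compounds below may be only part of what the source reports. "The series", "measured", "known", "first", "only" and "open" are said of these compounds alone.

Compound 1 `C=C(Br)C(=O)Nc1cccc(-c2cn3nc(-c4cccc(OC)c4)sc3n2)c1` and compound 2 `C=C(Br)C(=O)Nc1cccc(-c2cn3nc(-c4ccc(OC)c(OC)c4)sc3n2)c1` share one core and were tested in a functional assay on HeLa cells (Homo sapiens) for inhibition, read by cell counting, with a stated time of 4 days; a lower number here means a stronger inhibitor, a higher number a weaker inhibitor. Compound 1 gives 1100 nM, while compound 2 gives 610 nM. For the measured compounds named here, the single measured step shows a 1.8-fold lower number from compound 1 to compound 2 (0.26 log units; within the scatter), so compound 2 stands at the lower of the two numbers without being separable from compound 1. Compound 3 `C=C(Br)C(=O)Nc1cccc(-c2cn3nc(Cc4ccc(OC)cc4)sc3n2)c1` carries 4-methoxybenzyl in place of 3,4-dimethoxyphenyl on an aromatic carbon. That measured step concerns only an added methoxy, not a benzyl in place of a phenyl, so it bears weakly here. A modest rise is expected: a 3.3-fold higher number from compound 2 to compound 3 (0.52 log units; beyond the scatter). Compound 3 is estimated at 2000 nM, between 600 nM and 7000 nM.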

Compound 3, half-maximal inhibitory concentration: 2300 nM
For compound 3 the middle estimate is 1.2-fold (0.06 log units) below the measured one; the measured number falls inside the stated range.
By their numbers in this assay, from the lowest: compounds 2 and 1 (each within the scatter of the next); then compound 3.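

In this assay, a 3.8-fold higher number from compound 2 to compound 3 (0.58 log units; beyond the scatter) and a 2.1-fold higher number from compound 1 to compound 3 (0.32 log units; beyond the scatter) show that this position responds beyond the scatter when 4-methoxybenzyl replaces either methoxy-bearing phenyl group, something the added methoxy alone did not do. Both steps are modest, so inhibition weakens here but is not lost. Nothing available explains this rise. Each step changes the methylene link and the methoxy pattern together, so their separate contributions remain unresolved. As far as these compounds go, how an amine, a carboxylic acid or a longer chain would fare at this position also stays open.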